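Trading isopropoxy for 1-methoxy-1-methylethyl

The compounds below may be only part of what the source reports. "The series", "measured", "known", "first", "only" and "open" are said of these compounds alone.

Compound 2 `CC(C)OCC1n2cncc2CN([C@@H](C)c2ccc(Cl)cc2)S1(=O)=O` was tested in an assay on isolated protein for inhibition of Aromatase (Homo sapiens), tested at 1 uM (a lower number here means less inhibition, a higher number more inhibition at the concentration tested (going by the name of the read-out)), where compound 2 gives 23%. Among the compounds with values here, that is the lower of the two numbers measured so far. Compound 1 `C[C@@H](c1ccc(Cl)cc1)N1Cc2cncn2C(CC2(C)COC2)S1(=O)=O` shares the core with it; in this assay compound 1 gives 35%. Within the data shown here, the one measured step, a number 12 percentage points lower from compound 1 to compound 2 (beyond the scatter), came from putting isopropoxy in place of 3-methyloxetan-3-yl on a saturated chain carbon bound to a saturated ring carbon.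

Compound 3 `COC(C)(C)CC1n2cncc2CN([C@@H](C)c2ccc(Cl)cc2)S1(=O)=O` has not yet been measured. It differs from compound 2 by 1-methoxy-1-methylethyl in place of isopropoxy on a saturated chain carbon bound to a saturated ring carbon. Among the measured compounds shown here, the step from compound 1 to compound 2 is the only one bearing on this change, and it was modest; the present exchange swaps one small ether group for another at the same place, so only a small shift, if any, is expected, a number 3 percentage points higher from compound 2 to compound 3 (within the scatter). Compound 3 is therefore expected to give 26% in this assay, within a range from 10% to 42%.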

Compound 3, a percentage reported as inhibition, at one concentration (the size of the read-out at that concentration, not a potency): 17%
Estimate against measurement, compound 3: 9 percentage points above; low and high end bracket the measured number.
By their numbers in this assay, from the lowest: compounds 3 and 2 (each within the scatter of the next); then compound 1.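

In this assay the exchange of isopropoxy for 1-methoxy-1-methylethyl gives a number 6 percentage points lower from compound 2 to compound 3 (within the scatter) and so does not separate these two open-chain ethers at this place, on a saturated chain carbon bound to a saturated ring carbon. Against the 3-methyloxetan-3-yl group the new compound gives a number 18 percentage points lower from compound 1 to compound 3 (beyond the scatter) and thus joins compound 2, so both groups without a ring stand beyond the scatter from compound 1, the only one of the three with a ring in this group. No measurement at hand explains this difference.

On these data alone, with a single ring-bearing group among the three, it remains open whether the ring itself goes with the higher number. The compounds shown also say nothing about how an amine, a carboxylic acid or a longer chain at this place would read out.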